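This account rests on a few compounds, and the source may have more. Where it says the series, first, only, none or still open, it means among the compounds named here.

Compound 3 `N#C/N=C1\N(CCCCCOc2ccc(Cl)cc2)C(=O)C(c2ccccc2)N1c1ccncc1` gives the highest of the three numbers in a functional assay on NUGC cells (stomach, Homo sapiens) for cytotoxicity (a higher number here means a weaker inhibitor, a lower number a stronger inhibitor), at 3450 nM. Compound 1 `N#C/N=C1\N(CCCCCCOc2ccc(Cl)cc2)C(=O)CN1c1ccncc1` gives 386 nM and compound 2 `CCC1C(=O)N(CCCCCCOc2ccc(Cl)cc2)/C(=N\C#N)N1c1ccncc1` gives 406 nM; the step of a 1.1-fold higher number from compound 1 to compound 2 (0.02 log units; within the scatter) shows that ethyl on the saturated ring carbon stays within the scatter. Compound 4 `N#C/N=C1\N(CCCCCCOc2ccc(Cl)cc2)C(=O)C(c2ccccc2)N1c1ccncc1` differs from compound 3 by (4-chlorophenoxy)methyl in place of 4-chlorophenoxy on a saturated chain carbon, five bonds along the chain from an amide-type nitrogen in a ring, so its chain matches that of compounds 1 and 2 while it keeps the phenyl of compound 3. For the measured compounds named here, no measured step changes the chain alone, and no measured pair separates the chain from the phenyl, so the size of the step cannot be read from the data. The step of a 2.9-fold lower number from compound 3 to compound 4 (0.46 log units; beyond the scatter) is expected to be a fall in number, with wide uncertainty. Compound 4 is expected at 1200 nM, within 350 nM to 4000 nM.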

Compound 4, half-maximal inhibitory concentration: 3340 nM
Compound 4: the middle estimate sits 2.8-fold (0.44 log units) below what was measured, within the range that was stated.
By their numbers in this assay, from the lowest: compounds 1 and 2 (each within the scatter of the next); then compounds 4 and 3 (each within the scatter of the next).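

In this assay, lengthening the chain makes no readable difference when the phenyl is present (a 1.0-fold lower number from compound 3 to compound 4 (0.01 log units; within the scatter)). With the chain held, phenyl on the saturated ring carbon raises the number against ethyl (an 8.2-fold higher number from compound 2 to compound 4 (0.92 log units; beyond the scatter)) and against hydrogen (an 8.7-fold higher number from compound 1 to compound 4 (0.94 log units; beyond the scatter)), so among these compounds the rise follows the phenyl, not the chain. Nothing shown here explains these steps. On these data alone, whether chain length matters with hydrogen or ethyl on that ring carbon remains open. So does how a benzyl or a methyl there would compare with phenyl.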